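The source may report more compounds than this note shows. Statements on the series, on what has been measured and on what is new or still open speak of the compounds shown alone.

The series rests on a shared core carrying an imine-linked phenyl group. Compound 1 `COc1nc(C)nc(/N=C/c2ccccc2)n1` bears an unsubstituted phenyl ring, and in an ADME assay on Vero cells (Chlorocebus sabaeus) for cytotoxicity, read by MTT assay, with a stated time of 72 h (on this read-out higher numbers stand for weaker inhibition and lower numbers for stronger inhibition), compound 1 is recorded as "not determined" (no result reported). Compound 2 `COc1nc(C)nc(/N=C/c2ccc(C)cc2)n1` carries a methyl on the phenyl ring. In this assay compound 2 reaches only the limit > 50 ug/mL, which is a boundary of the measurement rather than a number. Compound 2 therefore stands at the limit described in the limit of > 50 ug/mL in this assay, at which 1 of the 2 values shown sits, with the other entry giving no number at all. Compound 3 `COc1nc(C)nc(/N=C/c2ccc(N(C)C)cc2)n1` differs from compound 2 by dimethylamino in place of methyl on an aromatic carbon. For the measured compounds named here, no step between measured compounds is available to calibrate this change, so the expectation is that the step from compound 2 to compound 3 in this assay is no larger than the usual scatter, expressed as a step that the limit leaves unreadable from compound 2 to compound 3. Compound 3 is thus estimated at 60 ug/mL, with a plausible range from 30 ug/mL to 150 ug/mL, most likely again reported only as a limit.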

Compound 3, half-maximal inhibitory concentration: > 50 ug/mL
Compound 3: no number, only a limit; the forecaster's own chance of this, stated with the estimate: 75%; the middle value lies beyond the limit too.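

Compound 2 and compound 3 both give only a limit in this assay, so no step can be read between them: the limit of > 50 ug/mL in this assay, at which 2 of the 3 values shown sit.

The compounds shown leave open what single value any of them would reach in this assay, and whether dimethylamino in place of methyl changes the read-out at all.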